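Swapping a methyl for a nitro on the urea aryl

The source may report more compounds than this note shows. Statements on the series, on what has been measured and on what is new or still open speak of the compounds shown alone.

Three ureas built on the same core have been tested in a functional assay on CRL2813 cells (Homo sapiens) for cytotoxicity, read by sulforhodamine B assay, with a stated time of 5 days; on this read-out lower numbers stand for stronger inhibition and higher numbers for weaker inhibition. Compound 1 `O=C(Nc1cccc(C(F)(F)F)c1)N[C@H]1CC[C@H](Oc2ccc(Cl)cc2)CC1` gives 2000 nM in this assay. Compound 2 `O=C(Nc1cccc(C(F)(F)F)c1)N[C@H]1CC[C@@H](Oc2ccc(F)cc2)CC1`, which differs in the halogen on its phenoxy ring, gives 2600 nM. Compound 3 `Cc1ccc(NC(=O)N[C@H]2CC[C@H](Oc3ccc(F)cc3)CC2)cc1`, carrying a 4-methylphenyl on the urea nitrogen, reaches no number at all in this assay: it sits at the limit > 20000 nM, as noted in the limit of > 20000 nM in this assay, at which 1 of the 3 values shown sits. So compound 3 stands apart from compounds 1 and 2 only as a limit, and how far beyond it lies cannot be told from the data.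

Compound 4 `O=C(Nc1ccccc1[N+](=O)[O-])N[C@H]1CC[C@H](Oc2ccc(F)cc2)CC1` is not yet measured. It is made from compound 3 by the change (2-nitrophenyl in place of 4-methylphenyl on an amide-type nitrogen). Among the compounds with values here, no pair of measured compounds shows this exact change, so the expected size of the step from compound 3 to compound 4 rests only on the spread of the numbers already seen. The step is expected to bring compound 4 back toward the range of compounds 1 and 2, an expected change of an at least 2.5-fold lower number from compound 3 to compound 4 (0.39 log units; beyond the scatter). Compound 4 is therefore expected to give about 8000 nM in this assay, with a likely range from 2000 nM to 30000 nM.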

Compound 4, half-maximal inhibitory concentration: 3500 nM
The estimate for compound 4 lay 2.3-fold (0.36 log units) above the measured number; the measured number falls inside the stated range.
By their numbers in this assay, from the lowest: compounds 1, 2 and 4 (each within the scatter of the next). At a limit, above all of these: compound 3.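

In this assay, putting 2-nitrophenyl in place of 4-methylphenyl on the amide-type nitrogen gives an at least 5.7-fold lower number from compound 3 to compound 4 (0.75 log units; beyond the scatter). Within the data shown here, this is the first step that can be read with only one place changed, and it shows that the group on this nitrogen can by itself move the number while the rest of the compound stays the same. Compound 3 sits at a limit, so the step gives only a minimum size, and its full size stays unknown: the limit of > 20000 nM in this assay, at which 1 of the 4 values shown sits.

The change replaces the methyl with a nitro and also alters where the substituent sits on the ring, and the compounds shown do not separate these two differences. A 2-methylphenyl or a 4-nitrophenyl on this nitrogen would tell them apart, and a 2-aminophenyl would show whether the nitro group itself is needed.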